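A few compounds are considered here, and "the series" means these few. Any claim that something is new, unique, unknown or untested is made for them only; others in the source may bear on it.

Compound 1 `COc1ccc(Nc2ncc(C(F)(F)F)c(N3Cc4cccc(N(C)S(C)(=O)=O)c4C3)n2)cc1C(F)(F)F` is tested in a functional assay on A549 cells (Homo sapiens) for antiproliferative activity, read by spectrophotometry, with a stated time of 2 days; on this read-out higher numbers stand for weaker inhibition of growth and lower numbers for stronger inhibition of growth. In this assay compound 1 gives > 30000 nM, which is a limit of the assay rather than a measured number (the limit of > 30000 nM in this assay, at which 1 of the 2 values shown sits). Compound 2 `CN(c1cccc2c1CN(c1nc(Nc3ccc(Cl)c(C(F)(F)F)c3)ncc1C(F)(F)F)C2)S(C)(=O)=O` differs from compound 1 only by chloro in place of methoxy on an aromatic carbon, and in this assay compound 2 gives 15200 nM. For the measured compounds named here, the resulting step, an at least 1.9-fold lower number from compound 1 to compound 2 (0.29 log units; that floor lies within the scatter), is the only measured step available, and since it starts from a limit its true size is unknown. Compound 3 `CN(c1cccc2c1CN(c1nc(Nc3cc(Cl)cc(C(F)(F)F)c3)ncc1C(F)(F)F)C2)S(C)(=O)=O` differs from compound 1 by 3-chloro-5-(trifluoromethyl)phenyl in place of 4-methoxy-3-(trifluoromethyl)phenyl on a nitrogen on an aromatic ring. Compound 3 thus shares with compound 2 the exchange of methoxy for chloro, so a step of similar direction and modest size is expected. Compound 3 is therefore estimated at 15000 nM, with a range from 5000 nM to 40000 nM, an expected step of an at least 2.0-fold lower number from compound 1 to compound 3 (0.30 log units; that floor lies within the scatter).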

Compound 3, concentration for 50% growth inhibition: 6700 nM
Beside the measured number, compound 3's estimate is 2.2-fold (0.35 log units) above it; the range from low to high includes it.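

Going to the 3-chloro-5-(trifluoromethyl)phenyl group on the same nitrogen gives, in this assay, a 2.3-fold lower number from compound 2 to compound 3 (0.36 log units; beyond the scatter), so moving chloro and trifluoromethyl around this ring, without changing which groups it carries, alters the read-out, something the earlier pair could not show. Replacing the 4-methoxy-3-(trifluoromethyl)phenyl group gives an at least 4.4-fold lower number from compound 1 to compound 3 (0.65 log units; beyond the scatter), and unlike the earlier floor, this one clears the scatter. Compound 1 stands at a limit of the assay, so this step has only a floor and no known size: the limit of > 30000 nM in this assay, at which 1 of the 3 values shown sits.

The compounds shown cannot tell what lies behind either step. On these data alone, whether a nitrile in place of the chloro, or an amine or a carboxylic acid on this ring, would keep or lose the lower number also remains open.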